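A Methylsulfonyl Swap on Compound 3

The compounds below may be only part of what the source reports. "The series", "measured", "known", "first", "only" and "open" are said of these compounds alone.

In a functional assay on HT-29 cells (Homo sapiens) for inhibition, read by CellTiter-Glo, with a stated time of 72 h (a higher number here means that more compound is tolerated, a lower number that less compound is tolerated), compound 3 `CC1=C(CC(=O)N(C)CCN(C)C(=O)[C@@H](N)C(C)C)c2cc(F)ccc2/C1=C\c1ccc([S+](C)[O-])cc1` gives 30200 nM. This lies within the scatter of compound 1 `CC1=C(CC(=O)N2CCN(CCCN(C)C)CC2)c2cc(F)ccc2/C1=C\c1ccc([S+](C)[O-])cc1` at 23800 nM, while compound 2 `CC1=C(CC(=O)N2CCN(c3ccncc3)CC2)c2cc(F)ccc2/C1=C\c1ccc([S+](C)[O-])cc1` shows a lower number at 9200 nM. In compound 4 `CC1=C(CC(=O)N(C)CCN(C)S(C)(=O)=O)c2cc(F)ccc2/C1=C\c1ccc([S+](C)[O-])cc1`, methylsulfonyl stands in place of (1-amino-2-methylpropyl)carbonyl on an amine nitrogen (methylsulfonyl in place of (1-amino-2-methylpropyl)carbonyl on an amine nitrogen). For the measured compounds named here, no measured step covers this exchange. The only one available, a 2.6-fold lower number from compound 1 to compound 2 (0.41 log units; beyond the scatter), is modest and concerns a different group, so it bears only loosely on the change. No shift beyond the scatter is therefore expected in this assay, and no direction can be favoured. The expected change is a 1.2-fold lower number from compound 3 to compound 4 (0.08 log units; within the scatter). Compound 4 is estimated at 25000 nM, with an expected range of 10000 nM to 60000 nM.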

Compound 4, half-maximal cytotoxic concentration: 12400 nM
The estimate for compound 4 lay 2.0-fold (0.30 log units) above the measured number; the measured number falls inside the stated range.
By their numbers in this assay, from the lowest: compounds 2, 4, 1 and 3 (each within the scatter of the next, the first and the last beyond it).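

In this assay, for the compounds shown here, the exchange of (1-amino-2-methylpropyl)carbonyl for methylsulfonyl on this amine nitrogen gives a 2.4-fold lower number from compound 3 to compound 4 (0.39 log units; beyond the scatter) and so shows that the group here can shift the number beyond the scatter, which no earlier step showed for this position. Against the two piperazine amides, the steps of a 1.3-fold higher number from compound 2 to compound 4 (0.13 log units; within the scatter) and a 1.9-fold lower number from compound 1 to compound 4 (0.28 log units; within the scatter) both stay within the scatter.

As far as these compounds go, whether an acetyl group or a bare amine on the same nitrogen would stay with compound 3 or with compound 4 remains open. No measurement at hand accounts for the step.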